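The compounds below may be only part of what the source reports. "The series", "measured", "known", "first", "only" and "open" are said of these compounds alone.

Measured so far in a functional assay on PC-3 cells (Homo sapiens), read by MTT assay, with a stated time of 48 h; a higher number here means a weaker inhibitor, a lower number a stronger inhibitor:
compound 1, `CCN(CC)CCNC(=O)c1ccc(C(CC)(CC)c2ccc(OCC(=O)C(C)(C)C)c(C)c2)n1CC`: 30 nM
compound 2, `CCN(CC)CCNC(=O)c1ccc(C(CC)(CC)c2ccc(OCC(O)C(C)(C)C)c(C)c2)n1CC`: 220 nM
compound 3, `CCn1c(C(=O)NCCN(C)C)ccc1C(CC)(CC)c1ccc(OCC(O)C(C)(C)C)c(C)c1`: 1630 nM

Compound 2 holds the second highest of the three numbers in this assay. Its nearest neighbour is compound 1, reached by a 7.3-fold higher number from compound 1 to compound 2 (0.87 log units; beyond the scatter); its furthest is compound 3, reached by a 7.4-fold higher number from compound 2 to compound 3 (0.87 log units; beyond the scatter). Both of these steps are beyond the scatter and of similar size, so compound 2 sits about midway between the two on the log scale.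

Compound 4, `CCn1c(C(=O)N(CCC#N)CCC#N)ccc1C(CC)(CC)c1ccc(OCC(O)C(C)(C)C)c(C)c1`, is not yet measured. It differs from compound 2 in one place: a group of 9 heavy atoms (6 carbon, 3 nitrogen; no ring) in place of a group of 8 heavy atoms (6 carbon, 2 nitrogen; no ring), on a carbonyl carbon.

Among the measured compounds shown here, only one measured step touches this part of the molecule: the change from compound 2 to compound 3, which alters the chain on the amide side and gave a 7.4-fold higher number from compound 2 to compound 3 (0.87 log units; beyond the scatter). The change to compound 4 is larger in kind, since the whole (2-(diethylamino)ethyl)amino group leaves and a group bearing two nitriles enters at the carbonyl carbon. The evidence from compound 3 points to the amide side being sensitive, so the step from compound 2 to compound 4 is expected to be a loss at least as large as that seen for compound 3, estimated at an 11-fold higher number from compound 2 to compound 4 (1.06 log units; beyond the scatter). Compound 4 is therefore estimated at 2500 nM in this assay, with a range from 500 nM to 12000 nM.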

Compound 4, half-maximal inhibitory concentration: 7800 nM
The estimate for compound 4 lay 3.1-fold (0.49 log units) below the measured number, and the stated range covers the measured number.
By their numbers in this assay, from the lowest: compound 1; then compound 2; then compound 3; then compound 4.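

In this assay, the position on the carbonyl carbon tolerates replacement of the whole side chain far less well than the earlier change within it suggested: the exchange of (2-(diethylamino)ethyl)amino for the group bearing two nitriles gives a 35-fold higher number from compound 2 to compound 4 (1.55 log units; beyond the scatter), a larger step than the swap of diethylamino for dimethylamino, a 7.4-fold higher number from compound 2 to compound 3 (0.87 log units; beyond the scatter). The weaker dimethylamino compound also leaves room for further loss at this carbonyl carbon, with a 4.8-fold higher number from compound 3 to compound 4 (0.68 log units; beyond the scatter), so the number in this assay keeps rising across the three side chains on the same core. No supporting evidence is available to explain this trend, and the change itself bundles together the loss of the amide hydrogen, the loss of the terminal amine and the arrival of two nitriles.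

The compounds shown cannot separate these contributions, so it remains open how a single 2-cyanoethylamino group, which keeps the amide hydrogen, would compare with compound 2 and compound 4. Also open, on these data alone, is how a pyrrolidine-terminated chain or a longer chain ending in diethylamino would read at this position, and whether the ketone of compound 1 would shift any of these steps.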